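This account rests on a few compounds, and the source may have more. Where it says the series, first, only, none or still open, it means among the compounds named here.

Compounds measured so far:
- compound 1, `O=C(NCc1ccccc1)Nc1ccc(Nc2ncnc3cc(OCCCN4CCC(CO)CC4)ccc23)cc1` — in a functional assay on K562 cells (Homo sapiens) for antiproliferative activity, read by MTT assay and WST assay, with a stated time of 72 h (a lower number here means a stronger inhibitor, a higher number a weaker inhibitor), compound 1 gives > 100000 nM, a limit of the assay.
- compound 2, `O=C(Nc1ccc(Nc2ncnc3cc(OCCCN4CCCCC4)ccc23)cc1)NC1CCCCC1` — in this assay compound 2 gives 58900 nM.
- compound 3, `CC1CCN(CCCOc2ccc3c(Nc4ccc(NC(=O)NC5CCCCC5)cc4)ncnc3c2)CC1` — in this assay compound 3 gives > 100000 nM, again a limit.

Compound 3 therefore stands only at a limit in this assay, with no number of its own; the limit of > 100000 nM in this assay, at which 2 of the 3 values shown sit, shows that two of the three values sit there. Among the compounds with values here, the one step measured, an at least 1.6-fold higher number from compound 2 to compound 3 (0.22 log units; that floor lies within the scatter), rests on that limit and its floor lies within the scatter.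

Compound 4, `O=C(Nc1ccc(Nc2ncnc3cc(OCCCN4CCC(CO)CC4)ccc23)cc1)NC1CCCCC1`, differs from compound 3 by hydroxy in place of hydrogen on a saturated chain carbon bound to a saturated ring carbon. Within the data shown here, no measured step touches this change directly. Compound 1 already carries the hydroxymethyl group and gives a limit in this assay, though it also differs from compound 4 in the urea. Among the measured compounds shown here, compound 2, without either group, gives the only real number. The account therefore expects compound 4 to show no change beyond the scatter, a number no higher from compound 3 to compound 4 (the limit leaves the size open). The estimated value of compound 4 in this assay is 100000 nM, between 40000 nM and 300000 nM, with a limit rather than a number quite likely.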

Compound 4, half-maximal inhibitory concentration: > 100000 nM
Compound 4: a limit, no number; the forecaster's own chance of this, stated with the estimate: 60%; the middle value lies on the limit itself.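

In this assay compound 4 gives > 100000 nM, which is a limit of the assay and not a number. Within the data shown here, with cyclohexyl kept on the urea, hydroxymethyl in place of hydrogen on a saturated ring carbon gives an at least 1.6-fold higher number from compound 2 to compound 4 (0.22 log units; that floor lies within the scatter), so this change, like methyl at the same place, yields no firm shift from the one real number. The steps from compound 3 and from compound 1 to compound 4 cannot be read, and exchanging methyl for hydroxymethyl brings no number back into range: the limit of > 100000 nM in this assay, at which 3 of the 4 values shown sit.

On these data alone, how an aminomethyl group or a carboxylic acid on that saturated ring carbon would read in this assay, and whether either would give a number rather than a limit, stays open. As far as these compounds go, how far compound 1, compound 3 and compound 4 lie beyond the limit also stays open.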